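Anilide series: cytotoxicity on PC-3 cells, step to compound 4

The source may hold more compounds than are shown below. What is called first, only, known or untested is meant among the compounds shown, and "the series" means these compounds.

Measured compounds:
compound 1 `CC(C)(C)OC(=O)c1cccc(NC(=O)C2CCCN(C(=O)c3cc(C(F)(F)F)cc(C(F)(F)F)c3)C2)c1` — 0%
compound 2 `O=C(Nc1cccc([N+](=O)[O-])c1)C1CCCN(C(=O)c2cc(C(F)(F)F)cc(C(F)(F)F)c2)C1` — 9%
compound 3 `O=C(Nc1ccc(Cl)cc1)C1CCCN(C(=O)c2cccc([N+](=O)[O-])c2)C1` — 0%

In an ADME assay on PC-3 cells (Homo sapiens) for cytotoxicity, read by WST assay, tested at 100 uM (a lower number here means less inhibition, a higher number more inhibition at the concentration tested (going by the name of the read-out)), compound 1 gives 0% and compound 3 gives 0%. Compound 2 gives 9%; this is the high end of the three numbers, but both other compounds lie within the usual scatter of it, so no order among the three can be read from these values. Among the compounds with values here, the one single-point step measured so far, a number 9 percentage points higher from compound 1 to compound 2 (within the scatter), is within the scatter.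

Compound 4 `O=C(Nc1cccc(OCCc2ccccn2)c1)C1CCCN(C(=O)c2cc(C(F)(F)F)cc(C(F)(F)F)c2)C1` has not yet been measured in this assay. It differs from compound 2 in one place: 2-(pyridin-2-yl)ethoxy in place of nitro on an aromatic carbon. Within the data shown here, no measured step covers this change; the only step that bears on the same position of the core, a number 9 percentage points higher from compound 1 to compound 2 (within the scatter), shows no movement beyond the scatter, and all three measured compounds sit in a narrow band. Therefore no step beyond the scatter is expected in this assay for compound 4, and the expected step is a number 4 percentage points lower from compound 2 to compound 4 (within the scatter). The estimate for compound 4 in this assay is 5%, with a range from -5% to 20%.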

Compound 4, a percentage reported as inhibition, at one concentration (the size of the read-out at that concentration, not a potency): 5%
Beside the measured number, compound 4's estimate shows no gap at the digits printed; measured number inside the range.
By their numbers in this assay, from the lowest: compounds 1, 3, 4 and 2 (each within the scatter of the next).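

At this aromatic carbon of the shared core, 2-(pyridin-2-yl)ethoxy in place of nitro adds a six-membered aromatic ring with 1 hetero atom and gives, in this assay, a number 4 percentage points lower from compound 2 to compound 4 (within the scatter). Set against tert-butoxycarbonyl at the same carbon, the same group gives a number 5 percentage points higher from compound 1 to compound 4 (within the scatter), so the three groups tried at this carbon, which differ widely in size and one of which carries a ring, remain within the scatter of one another at the single concentration tested. No measurement is available that could explain this flat picture.

The compounds shown leave open whether an amine or a carboxylic acid at this carbon would give a step beyond the scatter. The same question stands for a longer chain in place of the ethoxy part of 2-(pyridin-2-yl)ethoxy.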